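This account rests on a few compounds, and the source may have more. Where it says the series, first, only, none or still open, it means among the compounds named here.

Compound 3 (`CCC(=O)c1ccc(OCCCCOc2ccc(F)c(C(=O)O)c2)c(C)c1O`) is the starting point of this step, and for it the record in an assay on HEK293 cells for positive allosteric modulation of metabotropic glutamate receptor 3 (Rattus norvegicus), read by thallium flux, with a stated time of 2.5 min (on this read-out lower numbers stand for an effect already at smaller amounts and higher numbers for an effect only at larger amounts of compound), reads only "not determined" (no result reported), so it has no number to stand on. The two neighbouring compounds give the only measured anchors. Compound 1 (`Cc1c(OCCCCOc2ccc(C(=O)O)cc2Cl)ccc(C(=O)CC2CCCC2)c1O`) reaches in this assay only the limit > 10000 nM, which is a boundary of the measurement and not a value; this is the limit described by the limit of > 10000 nM in this assay, at which 1 of the 3 values shown sits. Compound 2 (`Cc1c(OCCCCOc2ccc(C(=O)O)c(Cl)c2)ccc(C(=O)CC(C)C)c1O`) gives in this assay 2050 nM. Compound 4 (`Cc1c(OCCCCOc2ccc(F)c(C(=O)O)c2)ccc(C(=O)CC2CCCC2)c1O`) is the compound still to be measured. It differs from compound 3 by cyclopentyl in place of methyl on a saturated chain carbon bound to a carbonyl carbon. Among the compounds with values here, with no measured step of this kind available, the size and direction of the change cannot be read from the data, and compound 1 shows that a cyclopentyl-bearing ketone can sit at the limit of this assay. Compound 4 is therefore estimated at 4000 nM, within a range from 800 nM to 20000 nM.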

Compound 4, half-maximal effective concentration: 2490 nM
Compound 4: the middle estimate sits 1.6-fold (0.21 log units) above what was measured; low and high end bracket the measured number.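

In this assay, putting 3-carboxy-4-fluorophenyl in place of 4-carboxy-2-chlorophenyl on an oxygen on a saturated carbon, with the cyclopentyl-bearing ketone kept, gives an at least 4.0-fold lower number from compound 1 to compound 4 (0.60 log units; beyond the scatter). The cyclopentyl ketone therefore does not rule out a measured number, since compound 4, which carries it, has the measured value 2490 nM. The true size of the step stays unknown, as compound 1 stands at a limit and not at a number: the limit of > 10000 nM in this assay, at which 1 of the 4 values shown sits.

Steps that involve compound 3 cannot be read, so the effect of cyclopentyl in place of methyl on a saturated chain carbon bound to a carbonyl carbon remains open. Also open, as far as these compounds go, is how an amide in place of the carboxylic acid would fare in this assay.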